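This account rests on a few compounds, and the source may have more. Where it says the series, first, only, none or still open, it means among the compounds named here.

- compound 1 `CN(C)CC(=O)N1CCC(NS(=O)(=O)c2cc(S(=O)(=O)c3ccccc3)ccc2C(F)(F)F)CC1` gives 100000 nM
- compound 2 `CC(C)(C)OC(=O)N1C(=O)CC[C@H]1C(=O)N1CCC(NS(=O)(=O)c2cc(S(=O)(=O)c3ccccc3)ccc2C(F)(F)F)CC1` gives 50000 nM

For the measured compounds named here, in a physicochemical assay for solubility (a lower number here means a less soluble compound, a higher number a more soluble compound), compound 2 stands at 50000 nM and so lies within the scatter of compound 1, the only other compound measured. Compound 3 `O=C1CC[C@@H](C(=O)N2CCC(NS(=O)(=O)c3cc(S(=O)(=O)c4ccccc4)ccc3C(F)(F)F)CC2)N1` has not yet been measured. It carries hydrogen in place of tert-butoxycarbonyl on an amide-type nitrogen in a ring and otherwise matches compound 2. Going by the values given here, no measured pair shows such a change, so only a modest move toward a higher number is expected, not beyond the scatter. The estimated step of a 1.4-fold higher number from compound 2 to compound 3 (0.15 log units; within the scatter) stays small. For compound 3 the expected value is 70000 nM with an estimated range (25000 nM to 150000 nM).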

Compound 3, solubility: 100000 nM
Compound 3: middle estimate off by 1.4-fold (0.15 log units), on the low side; the measured number falls inside the stated range.
By their numbers in this assay, from the lowest: compounds 2, 1 and 3 (each within the scatter of the next).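

In this assay hydrogen in place of tert-butoxycarbonyl on the amide-type nitrogen in the ring gives a 2.0-fold higher number from compound 2 to compound 3 (0.30 log units; within the scatter) at this position, so this change does not tell the two compounds apart. Likewise, 5-oxopyrrolidin-2-yl in place of (dimethylamino)methyl on a carbonyl carbon gives no change at the digits printed from compound 1 to compound 3 (within the scatter) and does not separate that pair. No evidence at hand bears on these readings. Still open, from the compounds shown here alone, is whether a methyl or an acetyl on that nitrogen, or a carboxylic acid in place of the 5-oxopyrrolidin-2-yl, would read beyond the scatter.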